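This account rests on a few compounds, and the source may have more. Where it says the series, first, only, none or still open, it means among the compounds named here.

Series so far, read in a physicochemical assay for lipophilicity, using the shake flask method, in phosphate buffer, measured as octanol-water partition, with a stated time of 2 h, at pH 7.4, tested at 1 uM; on this read-out higher numbers stand for higher lipophilicity and lower numbers for lower lipophilicity
- compound 1 `OC[C@H]1O[C@H](Oc2ccc(-n3ccc4ccccc43)cc2Cl)[C@@H](O)[C@@H](O)[C@@H]1O` gives 1.8
- compound 2 `OC[C@H]1O[C@H](Oc2ccc(-n3ccc4c(OCc5ccccc5)cccc43)cc2Cl)[C@@H](O)[C@@H](O)[C@@H]1O` gives 2.7

Compound 1 holds the lower of the two numbers. Compound 3 `OC[C@H]1O[C@H](Oc2ccc(-n3ccc4ccccc43)cc2F)[C@@H](O)[C@@H](O)[C@@H]1O` is still unmeasured. It keeps the core of compound 1 and carries fluoro in place of chloro on an aromatic carbon, in full (fluoro in place of chloro on an aromatic carbon). For the measured compounds named here, the only measured step, a number 0.90 log units higher from compound 1 to compound 2 (beyond the scatter), is benzyloxy in place of hydrogen on an aromatic carbon. Going by the values given here, it bears only loosely, since no measured step exchanges one halogen for another. It does give a yardstick for a modest step, and a smaller one is expected here, towards lower numbers in this assay, close to the edge of the scatter. The direction rests on general experience, not on data from this series. The estimated step is a number 0.30 log units lower from compound 1 to compound 3 (within the scatter) in size. For compound 3 the expected value is 1.5, with an estimated range from 1.1 to 1.8 as the outcome.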

Compound 3, distribution coefficient: 2.4
The estimate for compound 3 lay 0.90 log units below the measured number; measured number above the stated range.
By their numbers in this assay, from the lowest: compound 1; then compounds 3 and 2 (each within the scatter of the next).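

In this assay the halogen on the aromatic carbon ortho to a large group and meta to a 1H-indol-1-yl group is not a silent place, since fluoro in place of chloro gives a number 0.60 log units higher from compound 1 to compound 3 (beyond the scatter) in this series. One heavy atom replaces one heavy atom here, with no ring, hydrogen-bond donor, hydrogen-bond acceptor or net charge on either side, yet the step is called modest, as is a number 0.90 log units higher from compound 1 to compound 2 (beyond the scatter) with benzyloxy in place of hydrogen. Nothing at hand accounts for the direction of this step.

Open, on these data alone, is how bromo, methyl, nitrile or plain hydrogen would read at this place on the core of compound 1. Also open, as far as these compounds go, is whether fluoro in place of chloro gives a like step with the benzyloxy group of compound 2 present.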